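Notes on the step from compound 2 to compound 4

This account rests on a few compounds, and the source may have more. Where it says the series, first, only, none or still open, it means among the compounds named here.

Values in a functional assay on HeLa cells (Homo sapiens) for inhibition, read by MTT assay, with a stated time of 72 h (on this read-out higher numbers stand for weaker inhibition and lower numbers for stronger inhibition), are as follows
- compound 1 `COc1cc(NC(C)CCCNC(=O)NNC(=O)Nc2ccc(C(F)(F)F)cc2)c2ncccc2c1` gives 15000 nM
- compound 2 `COc1cc(NC(C)CCCNC(=O)NNC(=O)Nc2ccc(Br)cc2)c2ncccc2c1` gives 101000 nM
- compound 3 `COc1cc(NC(C)CCCNC(=O)NNC(=O)Nc2cccc(C(F)(F)F)c2)c2ncccc2c1` gives 4900 nM

Compound 2 has the highest number of the three, so it is the weakest inhibitor here. Compound 4 `COc1cc(NC(C)CCCNC(=O)Nc2ccc(Cl)cc2)c2ncccc2c1` is still unmeasured. The change is 4-chlorophenyl in place of ((4-bromophenyl)carbamoyl)amino on an amide-type nitrogen. The nearest guides are a 6.7-fold higher number from compound 1 to compound 2 (0.83 log units; beyond the scatter) and a 21-fold lower number from compound 2 to compound 3 (1.31 log units; beyond the scatter), one modest and one large. Neither covers a change of this kind, so the expectation is loose. A modest step to a lower number is expected in this assay, which would be a 3.4-fold lower number from compound 2 to compound 4 (0.53 log units; beyond the scatter) as estimated. For compound 4 the estimate is 30000 nM, within 6000 nM to 120000 nM as the expected range.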

Compound 4, half-maximal inhibitory concentration: 18000 nM
Compound 4: the middle estimate sits 1.7-fold (0.22 log units) above what was measured; low and high end bracket the measured number.
By their numbers in this assay, from the lowest: compound 3; then compounds 1 and 4 (each within the scatter of the next); then compound 2.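

In this assay, the smaller 4-chlorophenyl on this amide-type nitrogen keeps measurable inhibition, with a 5.6-fold lower number from compound 2 to compound 4 (0.75 log units; beyond the scatter), so activity at this position does not depend on retaining ((4-bromophenyl)carbamoyl)amino. The step removes the carbamoylamino unit and exchanges bromine for chlorine together, so the contribution of each cannot be separated. No available evidence bears on the origin of this step.

Open, as far as these compounds go, is how the 4-bromophenyl or 3-(trifluoromethyl)phenyl groups behave directly on this nitrogen. Also open, from the compounds shown here alone, is the effect of an amine or a carboxylic acid on this aromatic ring.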